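From Piperidine Side Chain to Free Hydroxy

This account rests on a few compounds, and the source may have more. Where it says the series, first, only, none or still open, it means among the compounds named here.

Of the compounds shown here, two with a shared core have been measured in an ADME assay on L6 cells (Rattus norvegicus) for cytotoxicity, with a stated time of 72 h; on this read-out higher numbers stand for weaker inhibition and lower numbers for stronger inhibition. Among the compounds with values here, compound 1 `CCN(CC)CC(=O)OC1CC2(N(C)C)CC(c3ccccc3)C1C(c1ccccc1)C2` gives 30100 nM, and compound 2 `CN(C)C12CC(OC(=O)CN3CCCCC3)C(C(c3ccccc3)C1)C(c1ccccc1)C2` gives 29300 nM, so compound 2 stands level with the only other number available. Compound 3 `CN(C)C12CC(O)C(C(c3ccccc3)C1)C(c1ccccc1)C2` differs from compound 2 by hydrogen in place of ((piperidin-1-yl)methyl)carbonyl on an oxygen on a saturated carbon. In words, this is hydrogen in place of ((piperidin-1-yl)methyl)carbonyl on an oxygen on a saturated carbon.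

Within the data shown here, only one measured step bears on this change, and only partly. Placing piperidin-1-yl in place of diethylamino gave a 1.0-fold lower number from compound 1 to compound 2 (0.01 log units; within the scatter). Among the measured compounds shown here, that step altered the end of the side chain but kept the chain, whereas compound 3 loses it entirely, and no measured compound shows the effect of such a loss. For the measured compounds named here, the flat result from the one swap argues against expecting a large move, though it cannot rule one out. A modest shift towards a higher number is therefore expected, held with little confidence, and the estimate is a 1.9-fold higher number from compound 2 to compound 3 (0.27 log units; within the scatter). Compound 3 is expected at 55000 nM, with an estimated range of 18000 nM to 170000 nM.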

Compound 3, half-maximal inhibitory concentration: 133000 nM
Compound 3: the middle estimate sits 2.4-fold (0.38 log units) below what was measured; low and high end bracket the measured number.
By their numbers in this assay, from the lowest: compounds 2 and 1 (each within the scatter of the next); then compound 3.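

In this assay, hydrogen in place of ((piperidin-1-yl)methyl)carbonyl on the oxygen gives a 4.5-fold higher number from compound 2 to compound 3 (0.66 log units; beyond the scatter), so this position responds to losing the whole side chain, although exchanging the amine at its end had left the number within the scatter. Hydrogen in place of ((diethylamino)methyl)carbonyl gives a step of nearly the same size, a 4.4-fold higher number from compound 1 to compound 3 (0.65 log units; beyond the scatter), so among these three compounds, either side chain goes with stronger inhibition than the free hydroxy, and the choice between the two amines makes no readable difference. Nothing in the data shown explains why the number climbs when the side chain leaves the oxygen.

The compounds shown leave open whether the stronger inhibition goes with the carbonyl on this oxygen or with the amine at the end of the chain, a question that a plain acetyl group on the oxygen would help to separate. From the compounds shown here alone, it also remains open whether a longer chain between the carbonyl and the piperidin-1-yl ring, or a carboxylic acid in place of the amine, would keep the number near that of the two esters.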